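Amide heteroaryl variation on the cyclopentyloxy-methoxybenzamide series

The source may report more compounds than this note shows. Statements on the series, on what has been measured and on what is new or still open speak of the compounds shown alone.

Among the measured compounds shown here, compound 2 `COc1ccc(C(=O)Nc2nccs2)cc1OC1CCCC1` gives 6500 nM in an assay on isolated protein for inhibition of phosphodiesterase 4A (Sus scrofa) (a lower number here means a stronger inhibitor, a higher number a weaker inhibitor), the highest of the two numbers so far; its nearest neighbour is compound 1 `COc1ccc(C(=O)Nc2cccnc2)cc1OC1CCCC1`, which in this assay gives 550 nM. For the measured compounds named here, the one measured step, a 12-fold higher number from compound 1 to compound 2 (1.07 log units; beyond the scatter), shows that the heteroaryl on the amide-type nitrogen moves the number strongly. Compound 3 `COc1ccc(C(=O)Nc2c(C)nsc2Br)cc1OC1CCCC1` is not yet measured; it differs from compound 2 by 5-bromo-3-methyl-1,2-thiazol-4-yl in place of 1,3-thiazol-2-yl on an amide-type nitrogen. Going by the values given here, no measured step covers this exchange, so only the size of the earlier step serves as a guide: a heteroaryl swap here can move the number well beyond the scatter, in either direction. For compound 3 the expected step is a 1.9-fold lower number from compound 2 to compound 3 (0.27 log units; within the scatter), with no firm direction. Compound 3 is therefore estimated at 3500 nM in this assay, within a range of 600 nM to 20000 nM.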

Compound 3, half-maximal inhibitory concentration: 500 nM
Beside the measured number, compound 3's estimate is 7.0-fold (0.85 log units) above it; measured number below the stated range.
By their numbers in this assay, from the lowest: compounds 3 and 1 (each within the scatter of the next); then compound 2.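

Notes on the heteroaryl on the amide-type nitrogen: in this assay the weak number of compound 2 does not extend to every five-membered aromatic ring with 2 hetero atoms, since a 13-fold lower number from compound 2 to compound 3 (1.11 log units; beyond the scatter) on exchanging 1,3-thiazol-2-yl for 5-bromo-3-methyl-1,2-thiazol-4-yl. The second new reading, a 1.1-fold lower number from compound 1 to compound 3 (0.04 log units; within the scatter) and thus no separation, places 5-bromo-3-methyl-1,2-thiazol-4-yl level with pyridin-3-yl at this position. No supporting data on the origin of the large step are available.

Going by these compounds, the exchange in compound 3 alters the ring and adds bromine and methyl at once, so the share of each in the step remains open. A 1,2-thiazol-4-yl without substituents, or one carrying only methyl, would help to divide that step, while a carboxylic acid in place of the bromine would test how far this position tolerates a different substituent.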